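Sulfur oxidation state on the shared core: working notes

The compounds below may be only part of what the source reports. "The series", "measured", "known", "first", "only" and "open" are said of these compounds alone.

compound 1 `Cn1c(-c2ccccc2F)nnc1[S+](C)[O-]` in a functional assay on the whole organism for antagonist activity, with Mus musculus as the target; on this read-out lower numbers stand for an effect already at smaller amounts and higher numbers for an effect only at larger amounts of compound: > 200 mg/kg
compound 2 `CCSc1nnc(-c2ccccc2F)n1C` in this assay: > 200 mg/kg

Compound 2 stands at the ceiling of the read-out: in this assay compound 2 gives > 200 mg/kg, which is a limit and not a number. Compound 1 likewise returns only a limit, > 200 mg/kg. Within the data shown here, the one step between measured compounds, a step that the two limits leave unreadable from compound 1 to compound 2, cannot be read because of the limit of > 200 mg/kg in this assay, at which 2 of the 2 values shown sit. Compound 3 `CCS(=O)(=O)c1nnc(-c2ccccc2F)n1C` differs from compound 2 by ethylsulfonyl in place of ethylsulfanyl on an aromatic carbon. Among the measured compounds shown here, no measured step bears on this change, since the single known step gives no size, so nothing in the data points in either direction. The working expectation for compound 3 in this assay is 250 mg/kg, with a range from 60 mg/kg to 1000 mg/kg, most probably reported once more as a limit. The expected step that the limit leaves unreadable from compound 2 to compound 3 is therefore none that could be told from the scatter.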

Compound 3, dose for half-maximal effect: > 200 mg/kg
Compound 3 was reported as a limit; the forecaster's own chance of this, stated with the estimate: 75%; the middle value is on the limit's open side.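

No step among compound 1, compound 2 and compound 3 can be read, because each value is a limit and not a number: the limit of > 200 mg/kg in this assay, at which 3 of the 3 values shown sit.

The compounds shown leave open whether any of these sulfur groups on the shared core gives a measurable dose in this assay, and how far the three differ.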